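Methyl on Selenium: What to Expect for Compound 4

The source may report more compounds than this note shows. Statements on the series, on what has been measured and on what is new or still open speak of the compounds shown alone.

Compound 1 `CCCCC[Se]c1nc(N)c2ccccc2n1` gives 28600 nM in a functional assay on MCF7 cells (Homo sapiens) for cytotoxicity, read by MTT assay, with a stated time of 72 h; on this read-out lower numbers stand for stronger inhibition of growth and higher numbers for weaker inhibition of growth.
Compound 2 `COc1ccc(CNc2nc([SeH])nc3ccccc23)cc1` gives 42700 nM.
Compound 3 `[SeH]c1nc(NCc2ccccc2)c2ccccc2n1` reaches only a limit of the assay, > 100000 nM.

Compound 3 therefore stands at the limit of > 100000 nM in this assay, at which 1 of the 3 values shown sits, the weakest position among the numbers shown, and because its value is only a limit, its step to compound 4 cannot be computed exactly. Compound 4 `C[Se]c1nc(NCc2ccccc2)c2ccccc2n1` differs from compound 3 by methyl in place of hydrogen on a selenium. Among the measured compounds shown here, the only measured step, an at least 2.3-fold higher number from compound 2 to compound 3 (0.36 log units; beyond the scatter), concerns a methoxy group on an aromatic carbon and does not bear on a change at selenium. Compound 1 also carries an alkyl chain on selenium, but differs in more than one place, so only its value can be noted. Compound 4 is estimated at 80000 nM, ranging from 25000 nM to 250000 nM. The expected step is an at least 1.2-fold lower number from compound 3 to compound 4 (0.09 log units; that floor lies within the scatter).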

Compound 4, concentration for 50% growth inhibition: 15800 nM
Compound 4: the middle estimate sits 5.1-fold (0.70 log units) above what was measured; the whole stated range lies above it.
By their numbers in this assay, from the lowest: compounds 4, 1 and 2 (each within the scatter of the next, the first and the last beyond it). At a limit, above all of these: compound 3.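

Methyl in place of hydrogen on a selenium gives an at least 6.3-fold lower number from compound 3 to compound 4 (0.80 log units; beyond the scatter) and so shows that growth inhibition in this assay responds to a change at this position, with only the one group altered. The full size of the step stays unknown because compound 3 stands at a limit: the limit of > 100000 nM in this assay, at which 1 of the 4 values shown sits.

As far as these compounds go, whether an ethyl group or a carboxylic acid on a short chain at the selenium would lower the number further remains open. So does whether a methoxy on the benzyl ring would add to the effect of the methyl.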